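The compounds below may be only part of what the source reports. "The series", "measured", "known", "first", "only" and "open" are said of these compounds alone.

Compound 1 `Cn1c(=O)c(S(=O)(=O)c2ccc(Cl)cc2)cc2cnc(Nc3ccc4[nH]ccc4c3)nc21` is the starting point of this comparison. In a functional assay on DU-145 cells (Homo sapiens) for inhibition, read by trypan blue exclusion, with a stated time of 72 h (a higher number here means a weaker inhibitor, a lower number a stronger inhibitor), compound 1 gives 250 nM, the lowest of the two numbers recorded so far. Among the compounds with values here, its only measured partner is compound 2 `Cn1c(=O)c(S(=O)(=O)c2ccc(Cl)cc2)cc2cnc(Nc3cccc4[nH]ccc34)nc21`, which in this assay gives 5000 nM. Within the data shown here, the one step recorded between measured compounds, a 20-fold higher number from compound 1 to compound 2 (1.30 log units; beyond the scatter), concerns the aromatic amine attached to the shared core and not the sulfonyl side.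

Compound 3 `Cn1c(=O)c(S(=O)(=O)c2ccc(F)cc2N)cc2cnc(Nc3ccc4[nH]ccc4c3)nc21` differs from compound 1 in that other region: 2-amino-4-fluorophenyl in place of 4-chlorophenyl on a sulfonyl sulfur. Among the measured compounds shown here, no measured step touches this part of the molecule, so the recorded step from compound 1 to compound 2 does not bear directly on it and gives no sign of the direction to expect. With nothing to point either way, the expectation for compound 3 is a step that stays within the usual scatter, or at most a modest one, in this assay. Compound 3 is therefore estimated at 300 nM, with a range from 80 nM to 1200 nM, which corresponds to an expected step of a 1.2-fold higher number from compound 1 to compound 3 (0.08 log units; within the scatter).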

Compound 3, half-maximal inhibitory concentration: 3000 nM
Compound 3: the middle estimate sits 10-fold (1.00 log units) below what was measured, outside the stated range (above it).
By their numbers in this assay, from the lowest: compound 1; then compounds 3 and 2 (each within the scatter of the next).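

The group on the sulfonyl sulfur is not a neutral part of the molecule: in this assay, replacing 4-chlorophenyl with 2-amino-4-fluorophenyl gives a 12-fold higher number from compound 1 to compound 3 (1.08 log units; beyond the scatter), even though the indol-5-yl group on the amine side stays the same. The sulfonyl side therefore responds to change, as the amine side did in a 20-fold higher number from compound 1 to compound 2 (1.30 log units; beyond the scatter), and compound 1 remains the strongest inhibitor of the three shown. No measurement here explains why this swap weakens inhibition.

The swap changes two things at once, since fluorine takes the place of chlorine and an amino group enters, so the compounds shown cannot tell whether one of these changes or the pair together accounts for the step; a phenyl ring carrying only the fluorine, or a chlorophenyl ring that also carries the amino group, would separate them. Also open, from the compounds shown here alone, is how an unsubstituted phenyl or a methoxyphenyl group on the sulfonyl sulfur would compare with the 4-chlorophenyl group of compound 1.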